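The compounds below may be only part of what the source reports. "The series", "measured", "known", "first", "only" and "open" are said of these compounds alone.

Measured compounds:
compound 1 `CCOC(=O)c1sc(-c2cccc(NC(=O)c3ccccc3)c2)nc1Nc1ccc(N2CCN(C)CC2)cc1` — 24800 nM
compound 2 `CN1CCN(c2ccc(Nc3nc(-c4cccc(NC(=O)c5ccccc5)c4)sc3C(=O)O)cc2)CC1` — "not determined" (no result reported)

In a functional assay on Ramos cells (Homo sapiens) for antiproliferative activity, read by CCK-8 assay, with a stated time of 72 h (on this read-out lower numbers stand for stronger inhibition and higher numbers for weaker inhibition), compound 1 gives 24800 nM. Compound 2 carries a carboxylic acid where compound 1 carries an ethyl ester, and in this assay compound 2 gives "not determined" (no result reported). No number exists for compound 2, so it stands without a value of its own, and nothing can be said about how it compares with compound 1.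

Compound 3 `CN1CCN(c2ccc(Nc3nc(-c4cccc(NC(=O)c5ccc(Cl)cc5)c4)sc3C(=O)O)cc2)CC1` has not yet been measured. It differs from compound 2 in a single place: chloro in place of hydrogen on an aromatic carbon. Among the compounds with values here, no pair of measured compounds shows what this change does in this assay, and compound 2 itself offers no number to build on. Within the data shown here, the only anchor is compound 1 with its weak result of 24800 nM, and compound 3 shares that core apart from the acid and the chloro. From the chloro in place of hydrogen no shift beyond the usual scatter is expected in this assay, in either direction. Compound 3 is expected to give about 30000 nM in this assay, within a range from 5000 nM to 100000 nM, with a real chance that only a limit is reported.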

Compound 3, half-maximal inhibitory concentration: 23300 nM
Beside the measured number, compound 3's estimate is 1.3-fold (0.11 log units) above it; the range from low to high includes it.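

No step can be read from this result: compound 2 has no number in this assay, so compound 3 has no partner that differs in one place only. No measurement on hand offers an explanation for the value of compound 3. From the compounds shown here alone, what the chloro alone does, and what the carboxylic acid in place of the ethyl ester does, both stay open.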